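Shortening the alpha-substituent of the aryloxy acid

This account rests on a few compounds, and the source may have more. Where it says the series, first, only, none or still open, it means among the compounds named here.

Three measured compounds share a diarylacetylene acid core. Compound 1 `CCS(=O)(=O)c1ccc(C)c(C#Cc2cc(Cl)ccc2OCC(=O)O)c1` gives 8.6 nM in an assay on CHO cells for displacement of a labelled ligand from prostaglandin D2 receptor 2 (Homo sapiens), read by scintillation counting; on this read-out lower numbers stand for stronger inhibition and higher numbers for weaker inhibition. Compound 3 `Cc1ccc(S(=O)(=O)CC(C)C)cc1C#Cc1cc(Cl)ccc1OCC(=O)O` gives 3 nM in this assay. Compound 2 `CCCS(=O)(=O)c1ccc(C)c(C#Cc2cc(Cl)ccc2OC(CC(C)C)C(=O)O)c1` gives 515 nM in this assay, the highest of the three numbers. How the core of compound 2 differs from that of compound 3 is not broken down here.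

The step of a 2.9-fold higher number from compound 3 to compound 1 (0.46 log units; beyond the scatter) follows the change (methyl in place of isopropyl on a saturated chain carbon bound to a sulfonyl sulfur). Compound 4 `CCCS(=O)(=O)c1ccc(C)c(C#Cc2cc(Cl)ccc2OC(CC)C(=O)O)c1` differs from compound 2 by methyl in place of isopropyl on a saturated chain carbon, two bonds along the chain from a carbonyl carbon and an oxygen on an aromatic ring. This is the same kind of change, but the place differs: in compound 3 the carbon is bound to a sulfonyl sulfur, while in compound 2 it is two bonds along the chain from a carbonyl carbon and an oxygen on an aromatic ring.

Compound 4 is estimated to reach 150 nM in this assay, within 40 nM to 600 nM. That expected step a 3.4-fold lower number from compound 2 to compound 4 (0.54 log units; beyond the scatter) rests on compound 1 giving 8.6 nM with an unbranched acid chain, against compound 2 at 515 nM.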

Compound 4, inhibition constant: 30 nM
For compound 4 the middle estimate is 5.0-fold (0.70 log units) above the measured one; measured number outside the range, below it.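

In this assay, methyl in place of isopropyl, on a saturated chain carbon two bonds along the chain from a carbonyl carbon and an oxygen on an aromatic ring, gives a 17-fold lower number from compound 2 to compound 4 (1.23 log units; beyond the scatter). The same exchange of groups therefore does not carry over as a fixed step in this series, and its direction reverses between the two pairs: the same change on two cores in this assay, a 2.9-fold higher number (0.46 log units; beyond the scatter) from compound 3 to compound 1 and a 17-fold lower number (1.23 log units; beyond the scatter) from compound 2 to compound 4, 49-fold (1.69 log units) apart, beyond the scatter of two such steps This does not show whether the place of the change or the rest of the core sets the difference, since the two pairs differ in both, and two pairs give no rule for any other compound.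

The compounds shown leave open how far the trend on the acid chain continues, for instance with a lone methyl or a cyclopropyl group in place of the ethyl of compound 4. They also leave open whether the 1-carboxypropoxy group would give a similar step with an ethyl or isobutyl chain on the sulfonyl group instead of the propyl chain.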